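A Nitro for a Methoxy on the Benzyl Arm

This account rests on a few compounds, and the source may have more. Where it says the series, first, only, none or still open, it means among the compounds named here.

Three oxime ethers built on one shared core have been measured in a functional assay on the whole organism (strain NMRI) with Mus musculus as the target, in the maximal electroshock model, with a stated time of 4 h; a higher number here means that more compound is needed for the effect, a lower number that less compound is needed. Compound 1 `COc1ccc(Cn2cc(CO/N=C/c3c(-c4ccc(C)cc4)nc4c(C)cccn34)nn2)cc1` carries a 4-methoxybenzyl group at its far end, and in this assay compound 1 gives 100 mg/kg, the highest of the three numbers. Compound 2 `C#CCO/N=C/c1c(-c2ccc(C)cc2)nc2c(C)cccn12` instead bears a short propargyl ether on the oxime, and in this assay compound 2 gives 40 mg/kg, which is the nearest to compound 1 yet still lies beyond the scatter below it. Compound 3 `C#CCO/N=C/c1c(-c2ccc(C)cc2)nc2ccc(Br)cn12` adds a bromine to the bicyclic part of the core and in this assay gives 20 mg/kg, the furthest from compound 1 and again beyond the scatter. No pair among these three differs in only one place, so no single step has been isolated.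

Compound 4 `Cc1ccc(-c2nc3c(C)cccn3c2/C=N/OCc2cn(Cc3ccc([N+](=O)[O-])cc3)nn2)cc1` keeps everything of compound 1 except one substituent: nitro in place of methoxy on an aromatic carbon. Within the data shown here, with no measured step of this kind to lean on, only a small change is expected. The step from compound 1 to compound 4 is estimated to be no change at the digits printed from compound 1 to compound 4 (within the scatter), none beyond the scatter. Compound 4 is therefore expected to give about 100 mg/kg in this assay, within a range from 50 mg/kg to 200 mg/kg.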

Compound 4, minimum effective dose: 40 mg/kg
The estimate for compound 4 lay 2.5-fold (0.40 log units) above the measured number; the whole stated range lies above it.
By their numbers in this assay, from the lowest: compounds 3, 2 and 4 (each within the scatter of the next); then compound 1.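

Among these compounds, for the first time a single change has been isolated: at the aromatic carbon para to a large group, with 4-nitrobenzyl in place of 4-methoxybenzyl, this assay shows a 2.5-fold lower number from compound 1 to compound 4 (0.40 log units; beyond the scatter) as a modest step. The substituent on this ring of the benzyl arm is therefore not indifferent to the read-out, although this conclusion rests on a single pair and says nothing about any other place in the molecule. No measured property of either group bears on this result, so the data offer no explanation for the step.

From the compounds shown here alone, it remains open whether the step is particular to nitro or would also appear with another group on the same carbon, such as an amine, a carboxylic acid or a nitrile, and whether a plain benzyl group would fall nearer to compound 1 or to compound 4. Also open, going by these compounds, is whether the same exchange would give a step of similar size on a core carrying a bromine, as compound 3 does.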